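Ring-Nitrogen Demethylation in a Dibromopyrrole Chalcone Series

The source may report more compounds than this note shows. Statements on the series, on what has been measured and on what is new or still open speak of the compounds shown alone.

Compound 1 `Cn1c(/C=C/C(=O)c2ccccc2O)cc(Br)c1Br` and compound 2 `Cn1c(/C=C/C(=O)c2ccc[nH]2)cc(Br)c1Br` differ in more than one place; the difference between the two cores is not broken down here. In a functional assay on MCF7 cells (Homo sapiens) for cytotoxicity, read by MTT assay, with stated times of 6 h and 48 h (a lower number here means a stronger inhibitor, a higher number a weaker inhibitor), compound 1 gives 2510 nM and compound 2 gives 450 nM. Compound 3 `O=C(/C=C/c1cc(Br)c(Br)[nH]1)c1ccccc1O` gives 1490 nM in this assay; the change from compound 1 to compound 3, (hydrogen in place of methyl on an aromatic nitrogen), made a 1.7-fold lower number from compound 1 to compound 3 (0.23 log units; within the scatter). Compound 4 `O=C(/C=C/c1cc(Br)c(Br)[nH]1)c1ccc[nH]1` carries the same kind of change on the core of compound 2, (hydrogen in place of methyl on an aromatic nitrogen); the surroundings differ only in wording, next to the ring atom that bears a group of 9 heavy atoms here, next to the ring atom that bears a large group for compound 3. Because a 1.7-fold lower number from compound 1 to compound 3 (0.23 log units; within the scatter) lies within the scatter, the expected step in this assay is a 1.5-fold lower number from compound 2 to compound 4 (0.18 log units; within the scatter). Compound 4 is estimated at 300 nM, between 120 nM and 800 nM.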

Compound 4, half-maximal inhibitory concentration: 72 nM
Compound 4: the middle estimate sits 4.2-fold (0.62 log units) above what was measured, outside the stated range (below it).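

On the core of compound 2, hydrogen in place of methyl on an aromatic nitrogen gives a 6.3-fold lower number from compound 2 to compound 4 (0.80 log units; beyond the scatter) in this assay. The size of this step does not carry over between the two cores: the same change on two cores in this assay, a 1.7-fold lower number (0.23 log units; within the scatter) from compound 1 to compound 3 and a 6.3-fold lower number (0.80 log units; beyond the scatter) from compound 2 to compound 4, 3.7-fold (0.57 log units) apart, beyond the scatter of two such steps

Going by these compounds alone, two pairs show only that the step differs between these cores; they do not show which structural difference between the cores goes with the larger step, or what size of step a further core would give.

Still open, on these data alone, is how a longer chain on that nitrogen, such as ethyl or propyl, would compare with hydrogen and methyl on each core. Also open, as far as these compounds go, is whether an amine or a carboxylic acid on the shared core would change the size of the step.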